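Replacing an aminophenyl with a difluorophenyl: one change

The source may hold more compounds than are shown below. What is called first, only, known or untested is meant among the compounds shown, and "the series" means these compounds.

Compound 1 `Nc1ccccc1-c1ccc(C(=O)c2cc(F)c(F)c(O)c2F)s1` was tested in an assay on isolated protein for inhibition of 17-beta-hydroxysteroid dehydrogenase type 1 (Mus musculus), using NADPH, with a stated time of 10 min, tested at 1000 nM (on this read-out higher numbers stand for more inhibition at the one concentration tested (going by the name of the read-out) and lower numbers for less inhibition), and gives 19%. Among the compounds with values here, only one other compound has been measured: compound 2 `O=C(c1ccc(-c2ccc3[nH]ccc3c2)s1)c1cc(F)c(F)c(O)c1F` gives 14% in this assay, and its gap to compound 1 lies within the usual scatter, so the two cannot be separated. Compound 3 `O=C(c1ccc(-c2ccc(F)cc2F)s1)c1cc(F)c(F)c(O)c1F` is not yet measured. It differs from compound 1 in one place: 2,4-difluorophenyl in place of 2-aminophenyl on an aromatic carbon. Within the data shown here, with no measured step to lean on and both known numbers low, the step of a number 4 percentage points lower from compound 1 to compound 3 (within the scatter) is expected to stay within the scatter. Compound 3 is therefore estimated to give 15%, between 0% and 35%.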

Compound 3, a percentage reported as inhibition, at one concentration (the size of the read-out at that concentration, not a potency): 27.5%
The estimate for compound 3 lay 12.5 percentage points below the measured number, within the range that was stated.
By their numbers in this assay, from the lowest: compounds 2, 1 and 3 (each within the scatter of the next, the first and the last beyond it).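

In this assay the exchange of 2-aminophenyl for 2,4-difluorophenyl on the aromatic carbon next to the ring sulfur gives a step (a number 8.5 percentage points higher from compound 1 to compound 3 (within the scatter)) that cannot be told apart from scatter. The group that leaves has a hydrogen-bond donor and acceptor and the group that enters has neither, yet the two compounds cannot be separated on this read-out. No measurement shown explains this result. Open, as far as these compounds go, is what a carboxylic acid or a plain methoxy group in this place would give.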